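Compound 3 against the two measured ureas-type analogues of compound 2

The source may hold more compounds than are shown below. What is called first, only, known or untested is meant among the compounds shown, and "the series" means these compounds.

Compound 1, `Cc1cccc(NC(=O)Nc2cccc(CNc3ncnc4ccccc34)c2)c1`, gives 30200 nM in a functional assay on A549 cells (Homo sapiens) for antiproliferative activity, read by MTT assay; a higher number here means a weaker inhibitor, a lower number a stronger inhibitor.
Compound 2, `Cc1ccc(NC(=O)Nc2cccc(CNc3ncnc4ccccc34)c2)cc1`, gives 24900 nM in this assay.

Among the measured compounds shown here, of these two numbers, the one for compound 2 is the smaller, but the step of a 1.2-fold lower number from compound 1 to compound 2 (0.08 log units; within the scatter) lies within the scatter, so the two compounds are not distinguished. Compound 3, `COc1ccccc1NC(=O)Nc1cccc(CNc2ncnc3ccccc23)c1`, differs from compound 2 by 2-methoxyphenyl in place of 4-methylphenyl on an amide-type nitrogen. For the measured compounds named here, the only measured step, a 1.2-fold lower number from compound 1 to compound 2 (0.08 log units; within the scatter), exchanges 3-methylphenyl for 4-methylphenyl and bears on a methoxy group not at all; nothing measured speaks directly to this change. Compound 3 is therefore expected to remain close to compound 2, with a step of a 1.1-fold higher number from compound 2 to compound 3 (0.05 log units; within the scatter) not expected to exceed the scatter. The estimate for compound 3 in this assay is 28000 nM, within 12000 nM to 70000 nM.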

Compound 3, half-maximal inhibitory concentration: 30800 nM
The estimate for compound 3 lay 1.1-fold (0.04 log units) below the measured number; the measured number falls inside the stated range.
By their numbers in this assay, from the lowest: compounds 2, 1 and 3 (each within the scatter of the next).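

In this assay, 2-methoxyphenyl in place of 4-methylphenyl on the amide-type nitrogen gives a 1.2-fold higher number from compound 2 to compound 3 (0.09 log units; within the scatter) and, in place of 3-methylphenyl, gives a 1.0-fold higher number from compound 1 to compound 3 (0.01 log units; within the scatter) at the same nitrogen. The earlier pair varied only where a methyl group stood, whereas this change brings in an oxygen and a hydrogen-bond acceptor and still moves the number by no more than the scatter. Nothing available explains this result.

The compounds shown leave open whether an amine or a carboxylic acid on this phenyl group, or a longer chain in its place, would shift the number beyond the scatter.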